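Side-chain trimming in a shared-core antiproliferative series

The source may hold more compounds than are shown below. What is called first, only, known or untested is meant among the compounds shown, and "the series" means these compounds.

Measured in a functional assay on NCI-H460 cells (Homo sapiens) for antiproliferative activity, read by MTT assay, with a stated time of 72 h; on this read-out lower numbers stand for stronger inhibition and higher numbers for weaker inhibition:
compound 1 `COCCOc1ccc2c(Oc3ccc(Nc4nccc5[nH]cc(-c6ccc(F)cc6)c(=O)c45)cc3F)ccnc2c1` gives 4300 nM
compound 2 `CC(C)(O)COc1ccc2c(Oc3ccc(Nc4nccc5[nH]cc(-c6ccc(F)cc6)c(=O)c45)cc3F)ccnc2c1` gives 3200 nM

Among the compounds with values here, compound 2 holds the lower of the two numbers in this assay, but its only neighbour is compound 1, and the step of a 1.3-fold lower number from compound 1 to compound 2 (0.13 log units; within the scatter) does not go beyond the scatter, so the two compounds cannot be ordered against each other.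

Compound 3 `CC(O)COc1ccc2c(Oc3ccc(Nc4nccc5[nH]cc(-c6ccc(F)cc6)c(=O)c45)cc3F)ccnc2c1` is not yet measured. It differs from compound 2 by hydrogen in place of methyl on a saturated chain carbon bound to an oxygen on a saturated carbon and two saturated chain carbons. Within the data shown here, the only measured step, from compound 1 to compound 2, also alters the tail of the same side chain and gave a 1.3-fold lower number from compound 1 to compound 2 (0.13 log units; within the scatter); that is the sole precedent bearing on the present change. It suggests the tail of this chain tolerates small changes without a shift beyond the scatter, though with one such step nothing firmer can be claimed.

The expectation for compound 3 is therefore a step of a 1.1-fold higher number from compound 2 to compound 3 (0.04 log units; within the scatter), i.e. no movement beyond the scatter. The estimated value for compound 3 in this assay is 3500 nM, with a range of 1500 nM to 8000 nM.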

Compound 3, half-maximal inhibitory concentration: 3400 nM
Beside the measured number, compound 3's estimate is 1.0-fold (0.01 log units) above it; measured number inside the range.
By their numbers in this assay, from the lowest: compounds 2, 3 and 1 (each within the scatter of the next).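

In this assay, taking the 2-hydroxy-2-methylpropoxy chain to the 2-hydroxypropoxy chain gives a 1.1-fold higher number from compound 2 to compound 3 (0.03 log units; within the scatter), so at this saturated chain carbon, the presence or absence of the methyl makes no difference that can be read. The wider comparison of the methoxymethyl tail with the 1-hydroxyethyl tail gives a 1.3-fold lower number from compound 1 to compound 3 (0.10 log units; within the scatter), also within the scatter, so compound 1, compound 2 and compound 3 form a single group in this assay and no ranking among them can be supported. No available measurement accounts for this result.

Methoxymethyl, 1-hydroxy-1-methylethyl and 1-hydroxyethyl are the only tails shown, so it remains open whether an amine, a carboxylic acid or a longer chain at this end of the side chain would move the number beyond the scatter. The shared core is also unchanged throughout, which leaves open whether compound 2, at 3200 nM, reflects what this core gives with any side chain or only with these closely related tails.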